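Plasma protein binding in a pyrrolidinyl-urea series

The source may report more compounds than this note shows. Statements on the series, on what has been measured and on what is new or still open speak of the compounds shown alone.

Measured compounds:
compound 1 `Nc1nccc(N2CC[C@H](NC(=O)Nc3ccc(Cl)c(C(F)(F)F)c3)C2)n1`: 99.4%
compound 2 `CNc1nccc(N2CC[C@H](NC(=O)Nc3ccc(OC(F)F)cc3)C2)n1`: 96.8%
compound 3 `CNc1nccc(N2CC[C@H](NC(=O)Nc3ccc(CN4CCN(C)CC4)c(C(F)(F)F)c3)C2)n1`: 85.8%

In an ADME assay on a cell-free system (plasma, Mus musculus) for protein binding, compound 1 gives 99.4%, the lowest unbound fraction of the three compounds measured. Compound 2 shows a larger unbound fraction than compound 1, and compound 3 a larger one still; both gaps are beyond the usual scatter, so compound 1 is the most strongly bound compound of the three.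

Compound 4 `O=C(Nc1ccc(Cl)c(C(F)(F)F)c1)N[C@H]1CCN(c2ccncn2)C1` has not been measured. It differs from compound 1 by a single change: hydrogen in place of amino on an aromatic carbon. Going by the values given here, no pair of measured compounds differs in just one place, so there is no measured step to lean on for this change.

Only a small step from compound 1 to compound 4 is expected in this assay, a 1.2-fold lower unbound fraction from compound 1 to compound 4 (0.08 log units; within the scatter), and no shift beyond the scatter is counted on, since compound 1 already sits near the top of the binding range with 99.4%. For compound 4 the expected value is 99.5%, with a range from 98.8% to 99.8%.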

Compound 4, plasma protein binding: 99.3%
For compound 4 the middle estimate is 1.4-fold (0.15 log units) (unbound fraction) below the measured one; low and high end bracket the measured number.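

Hydrogen in place of amino on the aromatic carbon between two ring nitrogen atoms gives a 1.2-fold higher unbound fraction from compound 1 to compound 4 (0.07 log units; within the scatter) in this assay and is the first single-place step available in this series. With the chloro and trifluoromethyl aryl urea held constant, the change from 2-aminopyrimidin-4-yl to pyrimidin-4-yl does not separate compound 1 from compound 4, so the high binding of compound 1 does not depend on the amino group. No measurement at hand accounts for this result.

Still open, going by these compounds, is whether a methoxy group, a dimethylamino group or a carboxylic acid on this carbon would give a step beyond the scatter. Also open, on these data alone, is whether the same exchange would read alike on compounds with the less strongly bound aryl urea of compound 3.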